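Changing the chain on the sulfonamide nitrogen

The compounds below may be only part of what the source reports. "The series", "measured", "known", "first", "only" and "open" are said of these compounds alone.

Two compounds share a core in which an acid-bearing aryl ether is linked through an alkyne to a sulfonyl-substituted ring. Compound 1 `Cc1ccc(S(=O)(=O)CC(C)C)cc1C#Cc1cc(Cl)ccc1OCC(=O)O` gives 3 nM in an assay on CHO cells for displacement of a labelled ligand from prostaglandin D2 receptor 2 (Homo sapiens), read by scintillation counting; a higher number here means a weaker inhibitor, a lower number a stronger inhibitor. Within the data shown here, compound 2 `Cc1ccc(S(=O)(=O)N(C)CC(C)C)cc1C#Cc1cc(Cl)ccc1OCC(=O)O` gives 4.2 nM in this assay and carries the highest of the two numbers so far, with compound 1 as its nearest neighbour. Among the measured compounds shown here, the only measured step, a 1.4-fold higher number from compound 1 to compound 2 (0.15 log units; within the scatter), shows that the group on the sulfonyl sulfur can be changed without a shift beyond the scatter. Compound 3 `Cc1ccc(S(=O)(=O)N(C)CCN(C)C)cc1C#Cc1cc(Cl)ccc1OCC(=O)O` differs from compound 2 by (dimethylamino)methyl in place of isopropyl on a saturated chain carbon bound to a sulfonamide nitrogen. For the measured compounds named here, no measured step replaces a hydrocarbon chain with one bearing a basic nitrogen, so the step of compound 1 to compound 2 bears only loosely on it. The expectation for compound 3 is a modest weakening, a 1.9-fold higher number from compound 2 to compound 3 (0.28 log units; within the scatter), giving an estimated 8 nM within 2.5 nM to 30 nM.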

Compound 3, inhibition constant: 369 nM
The estimate for compound 3 lay 46-fold (1.66 log units) below the measured number; the whole stated range lies below it.
By their numbers in this assay, from the lowest: compounds 1 and 2 (each within the scatter of the next); then compound 3.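

The earlier step on the sulfonyl sulfur stayed within the scatter and suggested a forgiving position, but the far end of the chain turns out to matter greatly: swapping isopropyl for (dimethylamino)methyl on a saturated chain carbon bound to a sulfonamide nitrogen gives an 88-fold higher number from compound 2 to compound 3 (1.94 log units; beyond the scatter). The loss is just as clear against the sulfone, with a 120-fold higher number from compound 1 to compound 3 (2.09 log units; beyond the scatter), so 2-(dimethylamino)ethyl is far less well accepted here than isobutyl, although the two chains differ little in size by the atom counts. Nothing available explains why this single change costs so much.

From the compounds shown here alone, it remains open whether the loss belongs to the dimethylamino group itself or would also appear with a chain ending in a hydroxyl group or a methyl ether. A longer chain carrying the same dimethylamino group, or a primary amine in its place, could help separate these possibilities.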